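This account rests on a few compounds, and the source may have more. Where it says the series, first, only, none or still open, it means among the compounds named here.

Compound 1 `COc1ccc(CS(=O)(=O)/C=C/c2c(OC)cccc2OC)c(N)c1`: 750 nM
Compound 2 `COc1cc(OC)c(/C=C/[S+]([O-])Cc2ccc(OC)c(N)c2)c(OC)c1`: 20 nM
Compound 3 `COC(=O)CNc1cc(CS(=O)(=O)/C=C/c2c(OC)cc(OC)cc2OC)ccc1OC`: 100 nM

In a functional assay on K562 cells (Homo sapiens) for cytotoxicity, read by trypan blue exclusion, with a stated time of 96 h (a higher number here means a weaker inhibitor, a lower number a stronger inhibitor), compound 3 holds the second highest of the three numbers: compound 2 is nearest, with a lower number beyond the scatter, and compound 1 is furthest, with a higher number, also beyond the scatter. Compound 4 `COc1cc(OC)c(/C=C/S(=O)(=O)Cc2ccc(OC)c(NC(C(=O)O)c3ccc(Cl)cc3)c2)c(OC)c1` is the compound still to be measured, and it differs from compound 3 in one place: carboxy(4-chlorophenyl)methyl in place of (methoxycarbonyl)methyl on a nitrogen on an aromatic ring. Going by the values given here, no pair of measured compounds that differ in a single place is available, so the size of this change cannot be read from a comparable step. The account expects a moderate move toward a higher number in this assay, beyond the scatter. The estimated step is a 2.5-fold higher number from compound 3 to compound 4 (0.40 log units; beyond the scatter). Compound 4 is therefore expected to give 250 nM, within a range from 50 nM to 1200 nM.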

Compound 4, half-maximal inhibitory concentration: 250 nM
Estimate against measurement, compound 4: no gap at the digits printed, within the range that was stated.
By their numbers in this assay, from the lowest: compound 2; then compound 3; then compound 4; then compound 1.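

Carrying carboxy(4-chlorophenyl)methyl in place of (methoxycarbonyl)methyl on a nitrogen on an aromatic ring gives, in this assay, a 2.5-fold higher number from compound 3 to compound 4 (0.40 log units; beyond the scatter), the first step in this set that can be read at a single place. The step is modest, although the entering group adds a six-membered aromatic ring and a hydrogen-bond donor. Nothing measured here accounts for its size.

The compounds shown leave open how much of the step belongs to the carboxylic acid and how much to the 4-chlorophenyl part. A methyl ester of the new group, or a plain phenyl in its place, would separate the two.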